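The source may report more compounds than this note shows. Statements on the series, on what has been measured and on what is new or still open speak of the compounds shown alone.

Measured compounds:
compound 2 `COc1ccc(/C=C\C(=O)O)c(OCc2cn(-c3ccccc3C#N)nn2)c1CC=C(C)C` — 8800 nM
compound 1 `COc1ccccc1-n1cc(COc2c(/C=C\C(=O)O)ccc(OC)c2CC=C(C)C)nn1` — "not determined" (no result reported)
compound 3 `COc1ccc(/C=C\C(=O)O)c(OCc2cn(-c3cccnc3Cl)nn2)c1CC=C(C)C` — "not determined" (no result reported)

Among the compounds with values here, in a functional assay on T47D cells (Homo sapiens) for cytotoxicity, read by MTT assay, with a stated time of 24 h (a lower number here means a stronger inhibitor, a higher number a weaker inhibitor), compound 2 gives 8800 nM, the only number so far; compound 1 and compound 3 carry no result in this assay, so no step between measured compounds can be drawn. Compound 4 `COc1ccc(/C=C\C(=O)O)c(OCc2cn(-c3nc4ccccc4s3)nn2)c1CC=C(C)C` differs from compound 2 by 1,3-benzothiazol-2-yl in place of 2-cyanophenyl on an aromatic nitrogen. Within the data shown here, with a single number and no measured step to lean on, no direction can be argued for this change; the expectation is a step from compound 2 to compound 4 of a 1.1-fold lower number from compound 2 to compound 4 (0.04 log units; within the scatter), within the usual scatter. Compound 4 is therefore estimated at 8000 nM, with a range from 3000 nM to 25000 nM.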

Compound 4, half-maximal inhibitory concentration: 17200 nM
For compound 4 the middle estimate is 2.2-fold (0.33 log units) below the measured one; low and high end bracket the measured number.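

In this assay, within the data shown here, the first readable step at this aromatic nitrogen is a 2.0-fold higher number from compound 2 to compound 4 (0.29 log units; within the scatter) for 1,3-benzothiazol-2-yl in place of 2-cyanophenyl. The position thus takes a group with a five-membered aromatic ring added and a sulfur, with no shift beyond the scatter, and the nitrile is not required for a number of this size. No measurement on hand bears on the reason for this result. Compound 1 and compound 3 carry no number, so steps to them cannot be read. As far as these compounds go, whether an aliphatic amine or a longer alkyl chain on this nitrogen would move the number beyond the scatter stays open.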